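The source may hold more compounds than are shown below. What is called first, only, known or untested is meant among the compounds shown, and "the series" means these compounds.

Compound 2 `COc1cc2cc(Oc3ccc(NC(=O)Nc4ccc(Cl)c(C(F)(F)F)c4)cc3)c(C)nc2cc1OC` gives 5790 nM in a functional assay on SK-OV-3 cells (Homo sapiens) for inhibition, read by sulforhodamine B assay, with a stated time of 48 h; on this read-out higher numbers stand for weaker inhibition of growth and lower numbers for stronger inhibition of growth; that is the lowest of the two numbers at hand, yet compound 1 `COc1cc2cc(Oc3ccc(NC(=O)Nc4cccc(C(F)(F)F)c4)cc3)c(C)nc2cc1OC` with 10600 nM stands within the usual scatter of it, so neither can be called stronger. Compound 3 `COc1cc2cc(Oc3ccc(NC(=O)Nc4ccc(Cl)c(Cl)c4)cc3)c(C)nc2cc1OC` differs from compound 2 by chloro in place of trifluoromethyl on an aromatic carbon. Going by the values given here, the only measured step nearby is a 1.8-fold lower number from compound 1 to compound 2 (0.26 log units; within the scatter), which shows a chloro on this ring barely moving the number. Trading the trifluoromethyl itself for chloro is a change the data do not test, so no step beyond the scatter is expected; compound 3 is estimated at 8000 nM (range 3000 nM to 22000 nM), an expected 1.4-fold higher number from compound 2 to compound 3 (0.14 log units; within the scatter).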

Compound 3, concentration for total growth inhibition: 26400 nM
The estimate for compound 3 lay 3.3-fold (0.52 log units) below the measured number; measured number outside the range, above it.
By their numbers in this assay, from the lowest: compounds 2 and 1 (each within the scatter of the next); then compound 3.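

Unlike the added chloro, which left the number within the scatter, replacing trifluoromethyl with chloro at this position weakens growth inhibition in this assay beyond the scatter (a 4.6-fold higher number from compound 2 to compound 3 (0.66 log units; beyond the scatter)). The loss also appears against the compound without the added chloro (a 2.5-fold higher number from compound 1 to compound 3 (0.40 log units; beyond the scatter)), so among these three compounds, the trifluoromethyl matters more than the added chloro. Nothing measured here gives a cause for this. From the compounds shown here alone, whether a methyl, a methoxy or a nitrile at this position would keep the number close to that of compound 2 remains open.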